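Shortening the chain on the shared core

The source may report more compounds than this note shows. Statements on the series, on what has been measured and on what is new or still open speak of the compounds shown alone.

compound 1 `CCC/C(=C\c1cc(OC)c(OC)c(OC)c1)C(=O)N1CCC=C(Br)C1=O`: 5020 nM
compound 2 `CCCC/C(=C\c1cc(OC)c(OC)c(OC)c1)C(=O)N1CCC=C(Br)C1=O`: 9210 nM

Both values come from an ADME assay on WI-38 cells (Homo sapiens) for cytotoxicity, read by MTT assay, with a stated time of 72 h (a higher number here means a weaker inhibitor, a lower number a stronger inhibitor), and stand within the scatter of each other, so compound 1 holds no clearly separate place on these numbers. Still unmeasured is compound 3 `CC/C(=C\c1cc(OC)c(OC)c(OC)c1)C(=O)N1CCC=C(Br)C1=O`, which differs from compound 1 on the same chain (hydrogen in place of methyl on a saturated chain carbon, two bonds along the chain from a double-bonded chain carbon). In words, this is hydrogen in place of methyl on a saturated chain carbon, two bonds along the chain from a double-bonded chain carbon, so that propyl becomes ethyl.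

Within the data shown here, only one measured step bears on this change: a 1.8-fold higher number from compound 1 to compound 2 (0.26 log units; within the scatter), for a methyl added one carbon further along the same chain. A single pair fixes no trend. A step of similar small size is therefore expected in this assay, leaning if anything towards a lower number, with none expected beyond the scatter. The estimated step is a 1.3-fold lower number from compound 1 to compound 3 (0.10 log units; within the scatter), and it remains only an expectation. For compound 3 the expected value is 4000 nM, with an estimated range from 1800 nM to 9000 nM, pending measurement.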

Compound 3, half-maximal inhibitory concentration: 7940 nM
Estimate against measurement, compound 3: 2.0-fold (0.30 log units) below; measured number inside the range.
By their numbers in this assay, from the lowest: compounds 1, 3 and 2 (each within the scatter of the next).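

Taking the chain from propyl to ethyl gives a 1.6-fold higher number from compound 1 to compound 3 (0.20 log units; within the scatter) in this assay and thus stays inside the scatter, as did the earlier methyl step further along the same chain. Among these compounds, the chain of compound 2 cut back to ethyl gives a 1.2-fold lower number from compound 2 to compound 3 (0.06 log units; within the scatter) on the same read-out, so all three compounds now lie within the scatter of one another and no dependence on chain length can be read across this span, which the single earlier pair could not show. Nothing measured on these compounds speaks to the reason for this flat reading.

Open, going by these compounds, is whether a group of another kind on this saturated chain carbon, such as a much longer chain, a phenyl ring, or a chain ending in an amine or a carboxylic acid, would move the number beyond the scatter. Also open, on these data alone, is whether the same flat reading across propyl and ethyl would hold on a core carrying something other than the bromine or the three methoxy groups of the shared core.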